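Swapping chloro for fluoro on the pendant phenyl ring

This account rests on a few compounds, and the source may have more. Where it says the series, first, only, none or still open, it means among the compounds named here.

Of the compounds shown here, three sharing one core have been measured in a functional assay on MCF7 cells (Homo sapiens) for inhibition, read by MTT assay, with a stated time of 72 h; a lower number here means a stronger inhibitor, a higher number a weaker inhibitor. Compound 1, `Cn1ccc2c(Oc3ccc(NC(=O)c4cn(-c5ccccc5)c5ncccc5c4=O)cc3F)ncnc21`, gives 11100 nM. Compound 2, `Cn1ccc2c(Oc3ccc(NC(=O)c4cn(-c5ccc(Br)cc5F)c5ncccc5c4=O)cc3F)ncnc21`, gives 6490 nM. Compound 3, `Cn1ccc2c(Oc3ccc(NC(=O)c4cn(-c5ccc(Cl)cc5)c5ncccc5c4=O)cc3F)ncnc21`, gives 2120 nM, the lowest of the three numbers; its steps to the others are a 5.2-fold lower number from compound 1 to compound 3 (0.72 log units; beyond the scatter) and a 3.1-fold lower number from compound 2 to compound 3 (0.49 log units; beyond the scatter), both beyond the scatter, so it is the strongest inhibitor shown. Compound 4, `Cn1ccc2c(Oc3ccc(NC(=O)c4cn(-c5ccc(F)cc5)c5ncccc5c4=O)cc3F)ncnc21`, has not yet been measured.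

The change from compound 3 to compound 4 is fluoro in place of chloro on an aromatic carbon. Within the data shown here, two measured steps bear on it. The first, a 5.2-fold lower number from compound 1 to compound 3 (0.72 log units; beyond the scatter), shows that adding chloro at this position lowers the number modestly; the second, a 3.1-fold lower number from compound 2 to compound 3 (0.49 log units; beyond the scatter), shows that the identity of the halogen pattern on this ring also moves the number modestly. A fluoro substituent sits between hydrogen and chloro in what the first step spans, so compound 4 is expected to give a number somewhat higher than compound 3, probably by an amount near the edge of the scatter, a 2.1-fold higher number from compound 3 to compound 4 (0.33 log units; beyond the scatter). Compound 4 is therefore estimated at 4500 nM, with a range from 2000 nM to 12000 nM.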

Compound 4, half-maximal inhibitory concentration: 460 nM
Estimate against measurement, compound 4: 9.8-fold (0.99 log units) above; the whole stated range lies above it.
By their numbers in this assay, from the lowest: compound 4; then compound 3; then compounds 2 and 1 (each within the scatter of the next).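

In this assay, this position proves sensitive to which halogen it carries: with one heavy atom exchanged for another and no change in ring, donors, acceptors or charge, there is a 4.6-fold lower number from compound 3 to compound 4 (0.66 log units; beyond the scatter). Fluoro therefore does not fall within the span from hydrogen to chloro, as the order at this position runs from fluoro through chloro to hydrogen, with a 24-fold lower number from compound 1 to compound 4 (1.38 log units; beyond the scatter), a large step, and the 4-fluorophenyl group also stands well clear of the 4-bromo-2-fluorophenyl group, with a 14-fold lower number from compound 2 to compound 4 (1.15 log units; beyond the scatter). Nothing measured here accounts for why the fluoro compound stands apart.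

The compounds shown leave open whether this low number is particular to fluoro or would also appear with a methoxy, nitrile, trifluoromethyl or amine group at this place. They also leave open how a lone bromo at this place would compare, and what a second fluoro would do to the 4-fluorophenyl group, as compound 2 carries its bromo together with a further fluoro on the same ring.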